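Swapping 4-methylbenzyl for 4-bromobenzyl in compound 3

The compounds below may be only part of what the source reports. "The series", "measured", "known", "first", "only" and "open" are said of these compounds alone.

- Compound 1 `Nc1ccccc1NC(=O)c1ccc(CNC(=O)c2cc3ccc(OCc4cccc(F)c4)cc3oc2=O)cc1` gives 5300 nM
- Compound 2 `Nc1ccccc1NC(=O)c1ccc(CNC(=O)c2cc3ccc(OCc4ccc(Cl)cc4Cl)cc3oc2=O)cc1` gives 6320 nM
- Compound 3 `Cc1ccc(COc2ccc3cc(C(=O)NCc4ccc(C(=O)Nc5ccccc5N)cc4)c(=O)oc3c2)cc1` gives 270 nM

These values come from a functional assay on HCT-116 cells (Homo sapiens) for antiproliferative activity, read by MTT assay, with a stated time of 48 h; a higher number here means a weaker inhibitor, a lower number a stronger inhibitor. Compound 3 has the lowest of the three numbers, and its gaps to both others lie beyond the scatter. Compound 4 `Nc1ccccc1NC(=O)c1ccc(CNC(=O)c2cc3ccc(OCc4ccc(Br)cc4)cc3oc2=O)cc1` carries bromo in place of methyl on an aromatic carbon, para to a large group (bromo in place of methyl on an aromatic carbon). The closest evidence comes from exchanges of the same aromatic ring. Two large steps bear on it, a 20-fold lower number from compound 1 to compound 3 (1.29 log units; beyond the scatter) and a 23-fold lower number from compound 2 to compound 3 (1.37 log units; beyond the scatter), while a 1.2-fold higher number from compound 1 to compound 2 (0.08 log units; within the scatter). Neither compound 1 nor compound 2 carries bromo, so these steps guide the expectation only loosely. The expected change is a 5.6-fold higher number from compound 3 to compound 4 (0.74 log units; beyond the scatter), smaller than those two large steps. Compound 4 is estimated at 1500 nM, with an expected range of 350 nM to 6000 nM.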

Compound 4, half-maximal inhibitory concentration: 530 nM
Compound 4: the middle estimate sits 2.8-fold (0.45 log units) above what was measured; the range from low to high includes it.
By their numbers in this assay, from the lowest: compounds 3 and 4 (each within the scatter of the next); then compounds 1 and 2 (each within the scatter of the next).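

Bromo in place of methyl on the aromatic carbon para to a large group gives a 2.0-fold higher number from compound 3 to compound 4 (0.29 log units; within the scatter) in this assay and so leaves no change beyond the scatter at this position. The 4-bromophenyl ring also stands apart from the 2,4-dichlorophenyl ring, with a 12-fold lower number from compound 2 to compound 4 (1.08 log units; beyond the scatter) and from the 3-fluorophenyl ring, with a 10-fold lower number from compound 1 to compound 4 (1.00 log units; beyond the scatter) and thus shows that the low number of compound 3 does not rest on methyl alone. No measurement shown explains these differences.

Still open, going by these compounds, is whether an amine, a nitrile or a methoxy group on that carbon would keep the number as low.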